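A few compounds are considered here, and "the series" means these few. Any claim that something is new, unique, unknown or untested is made for them only; others in the source may bear on it.

Compound 1 `CC(C)(C)C(=O)N(CCCCCCN1C[C@H](O)[C@@H](O)[C@H](O)[C@H]1CO)C1CCCCC1` gives in an ADME assay on BHK cells (Mesocricetus auratus) for cytotoxicity, read by MTT assay (a higher number here means that more compound is tolerated, a lower number that less compound is tolerated), a value of > 500000 nM, which is a limit of the assay rather than a number.
Compound 2 `CC(C)(C)CC(=O)N(CCCCCCN1C[C@H](O)[C@@H](O)[C@H](O)[C@H]1CO)C1CCCCC1` gives in this assay a value of > 500000 nM, likewise a limit.

Compound 1 therefore stands only at a limit in this assay; no measured number places it more precisely. Going by the values given here, the single measured step, a step that the two limits leave unreadable from compound 1 to compound 2, is left unreadable by the two limits, and the limit of > 500000 nM in this assay, at which 2 of the 2 values shown sit, is all that the evidence offers. Compound 3 `CC(C)(C)C(=O)N(CCCCCCN1C[C@H](O)[C@@H](O)[C@H](O)[C@H]1CO)C1CC1` differs from compound 1 by cyclopropyl in place of cyclohexyl on an amide-type nitrogen. Among the compounds with values here, no measured step touches this amide-type nitrogen substituent, and the one step that was measured, on the carbonyl carbon, cannot be sized, so there is no ground for expecting a change beyond the scatter in either direction. Compound 3 is expected to sit at 500000 nM, with a range from 200000 nM to 1000000 nM, most probably again only as a limit. The step expected is a number no higher from compound 1 to compound 3 (the limit leaves the size open).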

Compound 3, half-maximal cytotoxic concentration: > 500000 nM
Compound 3: no number, only a limit; the forecaster's own chance of this, stated with the estimate: 80%; the middle value sits exactly at the limit.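

Going by these compounds alone, compound 3, like compound 1, gives only a limit in this assay, so no step between these two compounds can be read. The compounds shown leave open how much of any of them is tolerated, and whether either change matters, with only this to go on: the limit of > 500000 nM in this assay, at which 3 of the 3 values shown sit.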